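Lengthening the linker of an amidine cytotoxicity lead

The source may hold more compounds than are shown below. What is called first, only, known or untested is meant among the compounds shown, and "the series" means these compounds.

Measured compounds:
- compound 1, `N=C(N)c1ccc2cc(-c3ccc(OCCCOc4ccccc4)cc3)oc2c1`: 8600 nM
- compound 2, `CC(C)NC(=N)c1ccc2cc(-c3ccc(OCCCOc4ccccc4)cc3)oc2c1`: 49900 nM

Compound 1 is the parent amidine. In an ADME assay on L6 cells (Rattus norvegicus) for cytotoxicity, read by resazurin assay, with a stated time of 70 h (on this read-out higher numbers stand for weaker inhibition and lower numbers for stronger inhibition), compound 1 gives 8600 nM, the lowest of the two numbers measured. Its nearest neighbour is compound 2, which carries an isopropyl in place of hydrogen on an amine nitrogen and gives 49900 nM; the step of a 5.8-fold higher number from compound 1 to compound 2 (0.76 log units; beyond the scatter) is modest but lies beyond the scatter.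

The unmeasured compound 3, `N=C(N)c1ccc2cc(-c3ccc(OCCCCOc4ccccc4)cc3)oc2c1`, keeps the amidine of compound 1 untouched and changes only the linker: phenoxymethyl in place of phenoxy on a saturated chain carbon, three bonds along the chain from an oxygen on an aromatic ring. Among the measured compounds shown here, the one measured step concerns the amidine nitrogen and so says nothing about the linker; no measured pair bears on this change. With no guidance from the data, the expectation is that compound 3 behaves like compound 1, with no step beyond the scatter in this assay. The estimated step is no change at the digits printed from compound 1 to compound 3 (within the scatter), and compound 3 is therefore expected to give 8600 nM, within a range from 4000 nM to 18000 nM.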

Compound 3, half-maximal inhibitory concentration: 14100 nM
For compound 3 the middle estimate is 1.6-fold (0.21 log units) below the measured one, and the stated range covers the measured number.
By their numbers in this assay, from the lowest: compounds 1 and 3 (each within the scatter of the next); then compound 2.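

Among the compounds shown here, the linker is the new information here: the earlier pair showed only what happens at the amidine nitrogen, whereas this result gives the first reading on the chain joining the shared core to the far phenyl ring. In this assay, putting phenoxymethyl in place of phenoxy on a saturated chain carbon, three bonds along the chain from an oxygen on an aromatic ring, gives a 1.6-fold higher number from compound 1 to compound 3 (0.21 log units; within the scatter) and so leaves the cytotoxicity reading indistinguishable from that of the parent, while isopropyl in place of hydrogen on an amine nitrogen gives a 5.8-fold higher number from compound 1 to compound 2 (0.76 log units; beyond the scatter), a step that does lie beyond the scatter. No measurement shown here accounts for either outcome, so the result stands as an observation without an explanation.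

On these data alone, this single step cannot show whether the chain can be extended further without a clear shift, so the readings for 2-phenoxyethyl or 3-phenoxypropyl at this place remain open, as does the effect of an amine or a carboxylic acid on the chain. As far as these compounds go, it also remains open whether isopropyl on the amine nitrogen of compound 3 would give a step like the one seen on the shorter chain.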